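Cyclopropyl lactone stereoisomers: compound 2 to compound 4

This account rests on a few compounds, and the source may have more. Where it says the series, first, only, none or still open, it means among the compounds named here.

The series is followed in a functional assay on MCF7 cells (Homo sapiens) for antiproliferative activity, read by luminescence and CellTiter-Glo, with a stated time of 48 h; on this read-out lower numbers stand for stronger inhibition and higher numbers for weaker inhibition. Compound 1 `COc1ccc(/C=C/[C@H]2CC=CC(=O)O2)cc1` returns only a limit of the assay, > 100000 nM. Compound 3 `O=C1C=CC[C@@H](/C=C/c2ccc([N+](=O)[O-])cc2)O1` likewise returns only a limit, > 100000 nM. Compound 2 `O=C1CCC[C@H]([C@@H]2C[C@H]2c2ccccc2)O1` also sits at a limit, giving > 100000 nM. No number is known for any of these compounds; every value shown is a limit, as summarised in the limit of > 100000 nM in this assay, at which 3 of the 3 values shown sit, so compound 2 stands level with the rest at the edge of what this assay reports, not at any measurable place within it.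

Compound 4 `O=C1CCC[C@H]([C@H]2C[C@@H]2c2ccccc2)O1` is not yet measured. It keeps every atom and bond of compound 2: the two compounds have the same atoms and bonds and differ only in configuration as drawn: 2 of 3 stereo elements differ; a stereocentre at a saturated ring carbon is drawn R in compound 2 and S in compound 4; a stereocentre at a saturated ring carbon is drawn R in compound 2 and S in compound 4. Within the data shown here, no step between measured compounds is available, so nothing in these data shows how a change of configuration alone moves the read-out in this assay. The step from compound 2 to compound 4 in this assay is expected to be a number no higher from compound 2 to compound 4 (the limit leaves the size open), nothing beyond the scatter. Compound 4 is expected to stay at the limit of this assay, so it is estimated at 100000 nM, with a range from 25000 nM to 400000 nM.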

Compound 4, half-maximal inhibitory concentration: > 100000 nM
Compound 4: no number, only a limit; the forecaster's own chance of this, stated with the estimate: 85%; the middle value lies on the limit itself.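

In this assay compound 4 gives > 100000 nM, a limit and not a number. Compound 2 also sits at a limit, so no step can be read between compound 2 and compound 4. On these data alone, whether configuration alone moves the read-out in this assay stays open.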